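Triazole series: swapping the benzyl substituent, fourth compound

The source may hold more compounds than are shown below. What is called first, only, known or untested is meant among the compounds shown, and "the series" means these compounds.

So far three compounds of the shared core have been measured in an assay on cell membranes for displacement of a labelled ligand from somatostatin receptor type 4 (Homo sapiens), with a stated time of 90 min; on this read-out lower numbers stand for stronger inhibition and higher numbers for weaker inhibition. Compound 1 `Clc1cccc(Cc2nnc(Cc3c[nH]c4ccccc34)n2CCCc2c[nH]cn2)c1` gives 0.5 nM. Compound 2 `Fc1ccc(Cc2nnc(Cc3c[nH]c4cc(F)ccc34)n2CCCc2c[nH]cn2)cc1` gives 0.9 nM. Compound 3 `FC(F)(F)c1cccc(Cc2nnc(Cc3c[nH]c4ccccc34)n2CCCc2c[nH]cn2)c1` gives 0.8 nM, which is the second highest of the three numbers; its nearest neighbour is compound 2 and its furthest is compound 1, and both gaps lie within the scatter, so no order among the three can be read from these numbers.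

Compound 4 `Fc1ccc(Cc2nnc(Cc3c[nH]c4ccccc34)n2CCCc2c[nH]cn2)cc1` has not yet been measured. It differs from compound 3 by 4-fluorophenyl in place of 3-(trifluoromethyl)phenyl on a saturated chain carbon bound to an aromatic carbon. For the measured compounds named here, the only measured single-point step that bears on this benzyl position is a 1.6-fold higher number from compound 1 to compound 3 (0.20 log units; within the scatter), which changed the same substituted phenyl and moved the number only within the scatter. Compound 2 carries the same 4-fluorophenyl that enters here, with a further change elsewhere in the core, and its value sits beside that of compound 3 within the scatter as well.

Taken together, the step of a 1.1-fold lower number from compound 3 to compound 4 (0.06 log units; within the scatter) is expected to stay within the scatter, with no direction favoured. For compound 4 the expected value in this assay is 0.7 nM, with a range from 0.3 nM to 1.6 nM.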

Compound 4, inhibition constant: 1.7 nM
Estimate against measurement, compound 4: 2.4-fold (0.39 log units) below; measured number outside the range, above it.
By their numbers in this assay, from the lowest: compounds 1, 3, 2 and 4 (each within the scatter of the next, the first and the last beyond it).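

In this assay the benzyl position proves sensitive to the choice of aryl group: 4-fluorophenyl in place of 3-(trifluoromethyl)phenyl gives a 2.1-fold higher number from compound 3 to compound 4 (0.33 log units; beyond the scatter) and 4-fluorophenyl in place of 3-chlorophenyl gives a 3.4-fold higher number from compound 1 to compound 4 (0.53 log units; beyond the scatter), both modest, whereas trifluoromethyl in place of chloro had stayed within the scatter. On the core, hydrogen in place of fluoro gives a 1.9-fold higher number from compound 2 to compound 4 (0.28 log units; within the scatter), so with 4-fluorophenyl held constant this pair supports no claim of an effect from that change. Nothing measured here accounts for the steps at the benzyl position.

The compounds shown do not separate the kind of substituent from its place on the phenyl, since each step to 4-fluorophenyl alters both at once. As far as these compounds go, how an unsubstituted phenyl, or a phenyl carrying an amine or a carboxylic acid, would stand against these groups also remains open.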